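This account rests on a few compounds, and the source may have more. Where it says the series, first, only, none or still open, it means among the compounds named here.

Compound 1 `COc1cc(C[C@H]2C(=O)OC[C@@H]2Cc2ccc(OC)c(OC)c2)ccc1N`: 2850 nM
Compound 2 `COc1cc(C[C@H]2C(=O)OC[C@@H]2Cc2ccc(OC)c(OC)c2)ccc1NC(=O)c1ccccc1`: > 50000 nM (a limit)
Compound 3 `COc1cc(C[C@H]2C(=O)OC[C@@H]2Cc2ccc(OC)c(OC)c2)ccc1Nc1ccccc1`: > 50000 nM (a limit)

These values come from a functional assay on A549 cells (Homo sapiens) for cytotoxicity, read by MTT assay, with a stated time of 4 days; a lower number here means a stronger inhibitor, a higher number a weaker inhibitor. Compound 3 has no exact number and stands only at the limit of > 50000 nM in this assay, at which 2 of the 3 values shown sit. Compound 4 `COc1cc(C[C@H]2C(=O)OC[C@@H]2Cc2ccc(OC)c(OC)c2)ccc1Nc1ccc([N+](=O)[O-])cc1` turns the phenyl of compound 3 into 4-nitrophenyl: nitro in place of hydrogen on an aromatic carbon. For the measured compounds named here, no measured step tests a nitro group directly. The nearest evidence is an at least 17-fold higher number from compound 1 to compound 3 (1.24 log units; beyond the scatter), and an at least 17-fold higher number from compound 1 to compound 2 (1.24 log units; beyond the scatter) is similar; both are large and weaken the compound. Compound 4 keeps the substituted nitrogen, so it is expected to stay weak, with no step beyond the scatter. The estimated change is a number no higher from compound 3 to compound 4 (the limit leaves the size open). For compound 4 the expected value is about 50000 nM, with an estimated range of 20000 nM to 100000 nM.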

Compound 4, half-maximal inhibitory concentration: 22100 nM
Estimate against measurement, compound 4: 2.3-fold (0.35 log units) above; the measured number falls inside the stated range.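

In this assay, for the compounds shown here, compound 4 is the first compound with a substituted nitrogen to give an exact number, so the ring carbon that carries the nitro group does affect activity: an at least 2.2-fold lower number from compound 3 to compound 4 (0.35 log units; beyond the scatter), and an at least 2.2-fold lower number from compound 2 to compound 4 (0.35 log units; beyond the scatter). Even so, the substituted nitrogen still weakens the compound, with a 7.8-fold higher number from compound 1 to compound 4 (0.89 log units; beyond the scatter). The full size of the gain from nitro stays open because compounds 2 and 3 stand only at a limit: the limit of > 50000 nM in this assay, at which 2 of the 4 values shown sit.

The step between compound 2 and compound 3 cannot be read. From the compounds shown here alone, whether an amine or a methoxy group in place of the nitro would act the same way also stays open.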